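The source may report more compounds than this note shows. Statements on the series, on what has been measured and on what is new or still open speak of the compounds shown alone.

Measured compounds in a functional assay on HT-29 cells (Homo sapiens) for cytotoxicity, read by MTT assay, with a stated time of 72 h; on this read-out lower numbers stand for stronger inhibition of growth and higher numbers for weaker inhibition of growth:
compound 1 `Sc1nc(NCc2ccccc2)c2ccccc2n1` gives 10100 nM
compound 2 `[SeH]c1nc(NCc2ccccc2)c2ccccc2n1` gives 62200 nM
compound 3 `C[Se]c1nc(NCc2ccccc2)c2ccccc2n1` gives 42800 nM

Compound 3 stands second highest of the three numbers; its nearest neighbour is compound 2, with a 1.5-fold lower number from compound 2 to compound 3 (0.16 log units; within the scatter), while compound 1 lies furthest away, with a 4.2-fold higher number from compound 1 to compound 3 (0.63 log units; beyond the scatter). Compound 4 `CSc1nc(NCc2ccccc2)c2ccccc2n1` has not yet been measured. It differs from compound 3 by a group of 2 heavy atoms (1 carbon, 1 sulfur; no ring) in place of a group of 2 heavy atoms (1 carbon, 1 selenium; no ring), on an aromatic carbon. Among the compounds with values here, two measured steps bear on this change. The step of a 6.2-fold higher number from compound 1 to compound 2 (0.79 log units; beyond the scatter) shows what the exchange of sulfur for selenium did on the unmethylated pair, and the step of a 1.5-fold lower number from compound 2 to compound 3 (0.16 log units; within the scatter) shows that adding the methyl on selenium left the number within the scatter. Taken together, compound 4 is expected to move back toward compound 1, so a step of roughly the size a 5.4-fold lower number from compound 3 to compound 4 (0.73 log units; beyond the scatter) is expected, giving a lower number in this assay. On that basis compound 4 is estimated at 8000 nM, with a range from 3000 nM to 20000 nM.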

Compound 4, concentration for 50% growth inhibition: 36500 nM
Beside the measured number, compound 4's estimate is 4.6-fold (0.66 log units) below it; measured number outside the range, above it.
By their numbers in this assay, from the lowest: compound 1; then compounds 4, 3 and 2 (each within the scatter of the next).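

In this assay, the exchange of selenium for sulfur at this aromatic carbon between two ring nitrogen atoms gives a 1.2-fold lower number from compound 3 to compound 4 (0.07 log units; within the scatter), and methylsulfanyl in place of the selenium atom of compound 2 gives a 1.7-fold lower number from compound 2 to compound 4 (0.23 log units; within the scatter), so with the methyl present the exchange no longer shows the gap seen without it, a 6.2-fold higher number from compound 1 to compound 2 (0.79 log units; beyond the scatter). The methyl on sulfur, by contrast, gives a 3.6-fold higher number from compound 1 to compound 4 (0.56 log units; beyond the scatter), while the methyl on selenium gives a 1.5-fold lower number from compound 2 to compound 3 (0.16 log units; within the scatter), so compound 1 alone stands apart from the other three compounds, with the lowest number. Nothing measured here accounts for this difference between compound 1 and the others.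

Going by these compounds, it remains open whether an amine, a hydroxyl group or a longer chain such as ethylsulfanyl at this carbon would fall with compound 1 or with the other three.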